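Swapping azidomethyl for diethylcarbamoyl on the shared core

The compounds below may be only part of what the source reports. "The series", "measured", "known", "first", "only" and "open" are said of these compounds alone.

Compound 1 `CC(C)=CCC[C@]1(C)/C=C/[C@@H](OC(=O)C=C(C)C)[C@](C)(O)/C=C/C(=O)/C(CN2CCCC2)=C\C1`: 140 nM
Compound 2 `CC(C)=CCC[C@]1(C)/C=C/[C@@H](OC(=O)C=C(C)C)[C@](C)(O)/C=C/C(=O)/C(CN=[N+]=[N-])=C\C1`: 3080 nM

In a functional assay on SMMC-7721 cells (Homo sapiens) for antiproliferative activity, read by MTT assay, with a stated time of 48 h (a lower number here means a stronger inhibitor, a higher number a weaker inhibitor), compound 2 gives 3080 nM, the higher of the two numbers and so the weaker inhibitor. Compound 3 `CCN(CC)C(=O)/C1=C/C[C@](C)(CCC=C(C)C)/C=C/[C@@H](OC(=O)C=C(C)C)[C@](C)(O)/C=C/C1=O` keeps the shared core but carries diethylcarbamoyl in place of azidomethyl on a double-bonded ring carbon. Within the data shown here, only one measured step bears on this change: a 22-fold higher number from compound 1 to compound 2 (1.34 log units; beyond the scatter). That large step, beyond the scatter, shows that the group at this place can matter greatly in this assay. It swaps a different pair of groups, however, and compound 3 has neither the pyrrolidin-1-yl of compound 1 nor the azido of compound 2. The data therefore give no direction, and no step beyond the scatter is expected, though the uncertainty is wide. The expected change is a 1.2-fold lower number from compound 2 to compound 3 (0.09 log units; within the scatter). For compound 3 the estimate is 2500 nM, with an expected range from 600 nM to 10000 nM.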

Compound 3, half-maximal inhibitory concentration: 13800 nM
Estimate against measurement, compound 3: 5.5-fold (0.74 log units) below; measured number outside the range, above it.
By their numbers in this assay, from the lowest: compound 1; then compound 2; then compound 3.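

In this assay, diethylcarbamoyl in place of azidomethyl gives a 4.5-fold higher number from compound 2 to compound 3 (0.65 log units; beyond the scatter), so this double-bonded ring carbon responds to a change even when neither group is the pyrrolidine-bearing one. Diethylcarbamoyl in place of (pyrrolidin-1-yl)methyl gives the far larger a 99-fold higher number from compound 1 to compound 3 (1.99 log units; beyond the scatter), which makes compound 1 the strongest inhibitor of the three and compound 3 the weakest, with every step among them beyond the scatter. Nothing measured here explains this order.

The three groups differ in several ways at once, so the compounds shown cannot tell whether the low number of compound 1 depends on the pyrrolidine ring or on having an amine nitrogen on a one-carbon link. A diethylaminomethyl or piperidin-1-ylmethyl group at this place would help separate those two readings.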